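A Chloro to Bromo Swap With One Number in Hand

This account rests on a few compounds, and the source may have more. Where it says the series, first, only, none or still open, it means among the compounds named here.

The series shares one core and varies only in the substituent on its aromatic ring. In a functional assay on Bel-7402 cells (Homo sapiens) for inhibition, read by MTT assay, with a stated time of 24 h, tested at 1 ug/mL (on this read-out higher numbers stand for more inhibition of growth at the one concentration tested and lower numbers for less inhibition of growth), compound 1 (`O=C(CCCCC1CCSS1)Nc1ccccn1`) is recorded as "not active" (no number reported) and has no number. Among the measured compounds shown here, compound 2 (`O=C(CCCCC1CCSS1)Nc1ccc(Cl)cn1`) gives 7.44% and so holds the only number available, which leaves no numerical comparison.

Compound 3 (`O=C(CCCCC1CCSS1)Nc1ccc(Br)cn1`) has not yet been measured. It carries bromo in place of chloro on an aromatic carbon, two atoms from the ring nitrogen and para to a large group: bromo in place of chloro on an aromatic carbon is the whole of the difference.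

For the measured compounds named here, no measured pair shows what such an exchange does in this assay, so no direction can be argued from the data. The expected a number 0.6 percentage points higher from compound 2 to compound 3 (within the scatter) is therefore none beyond the usual scatter, an expectation resting on compound 2 at 7.44% alone. A report without a number, like that for compound 1, also remains possible. Compound 3 is estimated at 8% in this assay, with an expected range from 1% to 20% around that figure.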

Compound 3, percent growth inhibition at one concentration: 13.1%
The estimate for compound 3 lay 5.1 percentage points below the measured number, and the stated range covers the measured number.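

Among the compounds shown here, the pair of compound 2 and compound 3 is the first with a number on both sides, so it gives the first reading of this exchange. In this assay, bromo in place of chloro on an aromatic carbon, two atoms from the ring nitrogen and para to a large group, gives a number 5.7 percentage points higher from compound 2 to compound 3 (within the scatter) and thus sets no order between the two compounds. On this read-out, at the one concentration tested, chloro and bromo at this place cannot be told apart, and nothing measured here offers an explanation for either value.

Still open, going by these compounds, is whether a different kind of group on the same aromatic carbon, such as an amine, a methoxy group or a carboxylic acid, would shift the result in this assay by more than the scatter. Also open, on these data alone, is how far either halogen compound truly stands from compound 1 , recorded as "not active" (no number reported) and therefore offering no number for a measured comparison with them.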